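From furan-2-yl to 1H-pyrazol-1-yl at the assay limit

A few compounds are considered here, and "the series" means these few. Any claim that something is new, unique, unknown or untested is made for them only; others in the source may bear on it.

Compound 1 (`CCN(c1ccc(C#N)c(Cl)c1)c1cc(-c2ccco2)ccc1C`) is the starting point of this step. In a functional assay on PC-3 cells (Homo sapiens) for antiproliferative activity, read by CCK-8 assay, with a stated time of 6 days (on this read-out higher numbers stand for weaker inhibition and lower numbers for stronger inhibition), compound 1 gives > 30000 nM, which is a limit of the assay and not a number. A second compound, compound 2 (`Cc1noc(C)c1-c1cccc2c1CCCN2c1ccc(C#N)c(C(F)(F)F)c1`), offers no comparison, since for compound 2 the entry reads "not determined" (no result reported).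

Compound 3 (`CCN(c1ccc(C#N)c(Cl)c1)c1cc(-n2cccn2)ccc1C`) keeps the core of compound 1 and carries 1H-pyrazol-1-yl in place of furan-2-yl on an aromatic carbon. Within the data shown here, both groups are five-membered aromatic rings, and no measured pair of compounds shows what such a swap does here.

In this assay the expected step is a number no higher from compound 1 to compound 3 (the limit leaves the size open), with no change expected beyond the usual scatter. Compound 3 is estimated at 30000 nM, with an expected range from 12000 nM to 60000 nM.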

Compound 3, half-maximal inhibitory concentration: 15700 nM
For compound 3 the middle estimate is 1.9-fold (0.28 log units) above the measured one, and the stated range covers the measured number.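

In this assay compound 1 gives > 30000 nM, which is a limit of the assay and not a number. Compound 3 gives 15700 nM, so with 1H-pyrazol-1-yl in place of furan-2-yl this position now has a single number, and the change brings an at least 1.9-fold lower number from compound 1 to compound 3 (0.28 log units; that floor lies within the scatter). That step is only a floor because one of its two ends is a limit: the limit of > 30000 nM in this assay, at which 1 of the 3 values shown sits.

As far as these compounds go, whether an amine, a carboxylic acid or a six-membered ring such as pyridine on this aromatic carbon would give a lower number stays open. The two rings also differ in more than one atom, so the compounds shown leave open which part of the swap goes with the step.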